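The source may report more compounds than this note shows. Statements on the series, on what has been measured and on what is new or still open speak of the compounds shown alone.

Working notes on the series. Within the data shown here, compound 1 `COc1ccc(-c2cc(/C=C/C(=O)c3ccc(N)cc3)[nH]n2)cc1` gives 67% in a functional assay on HCT-116 cells (Homo sapiens) for cytotoxicity, read by sulforhodamine B assay, with a stated time of 48 h, tested at 1 uM (a lower number here means a stronger effect, a higher number a weaker effect of the compound at the concentration tested), and holds the lowest of the three numbers so far. Among the measured compounds shown here, compound 2 `COc1cc(-c2cc(/C=C/C(=O)c3ccc(Cl)c(Cl)c3)[nH]n2)cc(OC)c1OC` gives 80% and compound 3 `COc1cc(-c2cc(/C=C/C(=O)c3ccc(F)c(F)c3)[nH]n2)cc(OC)c1OC` gives 113%; the only single-point step measured is a number 33 percentage points higher from compound 2 to compound 3 (beyond the scatter), and it concerns the carbonyl side, not the methoxy-bearing side. Compound 4 `COc1ccc(-c2cc(/C=C/C(=O)c3ccc(N)cc3)[nH]n2)cc1OC` differs from compound 1 by methoxy in place of hydrogen on an aromatic carbon. For the measured compounds named here, no measured step tells what a methoxy in place of hydrogen on an aromatic carbon does here; compound 2 and compound 3 carry more methoxy groups but also differ from compound 1 on the carbonyl side, so their numbers are not comparable point for point. The expectation is therefore no step beyond the scatter, a number 3 percentage points higher from compound 1 to compound 4 (within the scatter). Compound 4 is estimated at 70%, range 50% to 95%.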

Compound 4, a percentage reported as activity, at one concentration (the size of the read-out at that concentration, not a potency): 87%
The estimate for compound 4 lay 17 percentage points below the measured number; low and high end bracket the measured number.
By their numbers in this assay, from the lowest: compound 1; then compounds 2 and 4 (each within the scatter of the next); then compound 3.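

Methoxy in place of hydrogen on an aromatic carbon, ortho to a methoxy group, is the first single-point change measured on the methoxy-bearing side. In this assay it gives a number 20 percentage points higher from compound 1 to compound 4 (beyond the scatter) and thus a weaker effect at the concentration tested, so this position does not tolerate the change without loss. No evidence at hand bears on the reason for this step.

Going by these compounds, whether a hydroxy or an ethoxy group at this position gives a similar step remains open. Also open, on these data alone, is whether the methoxy step holds when the amine on the carbonyl side is replaced by chlorine or fluorine.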